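Swapping tert-Butyl for sec-Butyl on the Urea Nitrogen

The compounds below may be only part of what the source reports. "The series", "measured", "known", "first", "only" and "open" are said of these compounds alone.

Measured compounds in an assay on isolated protein for inhibition of histamine H2 receptor (Cavia porcellus); on this read-out lower numbers stand for tighter binding and higher numbers for weaker binding:
Compound 1 `O=C(NCCCOc1cccc(CN2CCCCC2)c1)Nc1ccccc1` gives 126 nM.
Compound 2 `O=C(NCCCOc1cccc(CN2CCCCC2)c1)Nc1ccc(C(F)(F)F)cc1` gives 1700 nM.
Compound 3 `CC(C)(C)NC(=O)NCCCOc1cccc(CN2CCCCC2)c1` gives 2090 nM.

Compound 3 has the highest number of the three. The step of a 1.2-fold higher number from compound 2 to compound 3 (0.09 log units; within the scatter) lies within the scatter, so compounds 2 and 3 cannot be told apart, whereas a 17-fold higher number from compound 1 to compound 3 (1.22 log units; beyond the scatter) is a large step. Compound 4 `CCC(C)NC(=O)NCCCOc1cccc(CN2CCCCC2)c1` differs from compound 3 in one place: sec-butyl in place of tert-butyl on an amide-type nitrogen. Going by the values given here, none of the measured steps exchanges one alkyl group for another on this nitrogen. The two large steps, a 13-fold higher number from compound 1 to compound 2 (1.13 log units; beyond the scatter) and a 17-fold higher number from compound 1 to compound 3 (1.22 log units; beyond the scatter), concern a trifluoromethyl on the aromatic ring and the exchange of phenyl for tert-butyl; neither bears directly on the present change. Among the compounds with values here, with no guiding step, the expectation in this assay is a change no larger than the scatter, and the step of a 1.0-fold lower number from compound 3 to compound 4 (0.02 log units; within the scatter) expresses that estimate. Compound 4 is therefore expected to give 2000 nM, within an estimated range of 800 nM to 5000 nM.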

Compound 4, dissociation constant: 95.5 nM
Compound 4: the middle estimate sits 21-fold (1.32 log units) above what was measured; the measured number lies below the stated range.
By their numbers in this assay, from the lowest: compounds 4 and 1 (each within the scatter of the next); then compounds 2 and 3 (each within the scatter of the next).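

In this assay, this amide-type nitrogen proves sensitive to how a butyl group is branched: sec-butyl and tert-butyl have the same four carbons and the same atom counts, yet the exchange gives a 22-fold lower number from compound 3 to compound 4 (1.34 log units; beyond the scatter). An aromatic ring is also not needed here, since a 1.3-fold lower number from compound 1 to compound 4 (0.12 log units; within the scatter) leaves sec-butyl and phenyl indistinguishable, while an 18-fold lower number from compound 2 to compound 4 (1.25 log units; beyond the scatter) sets sec-butyl clearly apart from 4-(trifluoromethyl)phenyl. No measurement at hand explains why two groups of identical composition behave so differently.

The compounds shown leave open whether tight binding depends on the exact sec-butyl shape or would also hold for an isopropyl group, a straight n-butyl chain or a cyclobutyl ring. They also leave open how the two mirror-image forms of sec-butyl compare with each other.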